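A Larger Ring Where Only Limits Exist

The compounds below may be only part of what the source reports. "The series", "measured", "known", "first", "only" and "open" are said of these compounds alone.

In a functional assay on A549 cells (Homo sapiens), read by MTT assay, with a stated time of 72 h (a lower number here means a stronger inhibitor, a higher number a weaker inhibitor), compound 3 (`Nc1nc2c(c(-c3ccccc3)cn2[C@@H]2O[C@H](CO)[C@@H](O)[C@H]2O)c(=O)[nH]1`) gives > 100000 nM as its reading, which is a limit and not a number. Compound 1 (`Nc1nc2c(c(-c3ccoc3)cn2[C@@H]2O[C@H](CO)[C@@H](O)[C@H]2O)c(=O)[nH]1`) has > 20000 nM as its reading, also a limit. Compound 2 (`Nc1nc2c(c(-c3ccsc3)cn2[C@@H]2O[C@H](CO)[C@@H](O)[C@H]2O)c(=O)[nH]1`) has > 20000 nM as its reading, again a limit.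

Compound 4 (`Nc1nc2c(c(-c3cc4ccccc4o3)cn2[C@@H]2O[C@H](CO)[C@@H](O)[C@H]2O)c(=O)[nH]1`) carries 1-benzofuran-2-yl in place of phenyl on an aromatic carbon. Three ring swaps bear on this change, and none of them gives a size: there is a step that the two limits leave unreadable from compound 1 to compound 2 and a step that the two limits leave unreadable from compound 1 to compound 3 and also a step that the two limits leave unreadable from compound 2 to compound 3 in the same series. Among the compounds with values here, no measured step therefore sets a size or a direction for this change, and weak inhibition is the only expectation these compounds support. The estimated step is an at least 2.0-fold lower number from compound 3 to compound 4 (0.30 log units; that floor lies within the scatter) and it is a rough expectation only. Compound 4 is expected near 50000 nM with an estimated range from 15000 nM to 150000 nM and the assay may well report only a limit again.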

Compound 4, half-maximal inhibitory concentration: > 100000 nM
Compound 4: a limit, no number; the forecaster's own chance of this, stated with the estimate: 85%; middle value at least 2.0-fold (0.30 log units) away from the limit.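

In this assay, compound 4 gives only a limit, as do compound 1, compound 2 and compound 3, so the steps to compound 4 from these three cannot be read. The compounds shown leave open how strongly any of the four inhibits, and whether changing this ring alters that at all.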